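The source may report more compounds than this note shows. Statements on the series, on what has been measured and on what is new or still open speak of the compounds shown alone.

Three compounds built on one shared core have been examined. Compound 1 `Cc1cc(C(=O)O)c(C)n1-c1cccc(Cl)c1` in an assay on cells for inhibition of Palmitoleoyl-protein carboxylesterase NOTUM variant C330S (Homo sapiens), read by fluorescence, with a stated time of 40 min (on this read-out lower numbers stand for stronger inhibition and higher numbers for weaker inhibition), gives 430 nM. Compound 2 `Cc1cc(C(=O)O)c(C)n1-c1ccc(Cl)cc1` carries the same atoms joined differently; the difference between the two cores is not broken down here, and in this assay compound 2 gives 860 nM. Compound 3 `Cc1cc(C(=O)O)c(C)n1-c1cccc(Cl)c1Cl` arises from compound 1 by chloro in place of hydrogen on an aromatic carbon and in this assay compound 3 gives 220 nM, a step of a 2.0-fold lower number from compound 1 to compound 3 (0.29 log units; within the scatter).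

Compound 4 `Cc1cc(C(=O)O)c(C)n1-c1ccc(Cl)cc1Cl` arises from compound 2 by chloro in place of hydrogen on an aromatic carbon, the same kind of change, though here the entering group is meta to a chloro group rather than ortho to a chloro group. From compound 2 to compound 4 a step of a 2.0-fold lower number from compound 2 to compound 4 (0.30 log units; within the scatter) is expected in this assay, resting on the step of a 2.0-fold lower number from compound 1 to compound 3 (0.29 log units; within the scatter). Compound 4 is therefore estimated at 430 nM, between 180 nM and 1000 nM.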

Compound 4, half-maximal inhibitory concentration: 430 nM
Compound 4: middle estimate and measured number agree at the digits printed; low and high end bracket the measured number.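

In this assay, chloro in place of hydrogen on an aromatic carbon gives a 2.0-fold lower number from compound 2 to compound 4 (0.30 log units; within the scatter). Set beside the earlier case, the change carries over from one core to the other with a step of matching size: the same change on two cores in this assay, a 2.0-fold lower number (0.29 log units; within the scatter) from compound 1 to compound 3 and a 2.0-fold lower number (0.30 log units; within the scatter) from compound 2 to compound 4, 1.0-fold (0.01 log units) apart, within the scatter of two such steps. Each step on its own lies within the scatter, however, so this agreement does not establish that the chloro group strengthens inhibition on either core, and two cores cannot show how far the match extends across the series.

The compounds shown leave open whether a fluoro, methyl or methoxy group in the same place would give a step of like size. They also leave open what an amide or a tetrazole in place of the carboxylic acid would do.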